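The compounds below may be only part of what the source reports. "The series", "measured", "known", "first", "only" and "open" are said of these compounds alone.

Working notes on the series. Compound 1 `CCC(=O)O[C@@H]1CO[C@H]2[C@@H]1OC[C@@H]2OC(=O)c1ccccc1OC(C)=O` gives 0.0608 h in an ADME assay on a cell-free system (plasma, Homo sapiens) for metabolic stability, with Plasma (Rattus norvegicus) as the target, read by HPLC, at pH 7.4 (a higher number here means that the compound lasts longer, a lower number that the compound disappears faster), the highest of the three numbers in hand. Compound 2 `CC(=O)Oc1ccccc1C(=O)O[C@H]1CO[C@H]2[C@@H]1OC[C@H]2OC(=O)C1CC1` gives 0.0322 h and compound 3 `CC(=O)Oc1ccccc1C(=O)O[C@H]1CO[C@H]2[C@@H]1OC[C@H]2OC(=O)c1cc(C)nc(Cl)c1` gives 0.0193 h. Of the measured steps, a 1.9-fold lower number from compound 1 to compound 2 (0.28 log units; within the scatter) and a 1.7-fold lower number from compound 2 to compound 3 (0.22 log units; within the scatter) stay within the scatter, whereas a 3.2-fold lower number from compound 1 to compound 3 (0.50 log units; beyond the scatter) lies beyond it. Compound 4 `CC(=O)Oc1ccccc1C(=O)O[C@H]1CO[C@H]2[C@@H]1OC[C@H]2OC(=O)c1ccccc1CO[N+](=O)[O-]` differs from compound 1 in one place: 2-((nitrooxy)methyl)phenyl in place of ethyl on a carbonyl carbon. The step from compound 1 to compound 3, where a ring group also took the place of ethyl on the carbonyl carbon, bears most directly on this change, so a modest lowering is expected. The expected step is a 2.4-fold lower number from compound 1 to compound 4 (0.39 log units; beyond the scatter). For compound 4 the estimate in this assay is 0.025 h, with a range from 0.012 h to 0.05 h.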

Compound 4, half-life: 0.045 h
The estimate for compound 4 lay 1.8-fold (0.26 log units) below the measured number; the range from low to high includes it.
By their numbers in this assay, from the lowest: compounds 3, 2, 4 and 1 (each within the scatter of the next, the first and the last beyond it).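

Replacing ethyl or cyclopropyl with 2-((nitrooxy)methyl)phenyl leaves a 1.4-fold lower number from compound 1 to compound 4 (0.13 log units; within the scatter) and a 1.4-fold higher number from compound 2 to compound 4 (0.15 log units; within the scatter) in this assay so a ring group of 11 heavy atoms on this carbonyl carbon does not by itself bring a shorter half-life. The ring groups are not interchangeable, with a 2.3-fold higher number from compound 3 to compound 4 (0.37 log units; beyond the scatter) on going from 2-chloro-6-methylpyridin-4-yl to 2-((nitrooxy)methyl)phenyl, so the lowering seen with compound 3 cannot be assigned to any ring at this place. Nothing at hand explains this difference. On these data alone, whether an unsubstituted phenyl or a longer alkyl chain here would stand with compound 4 or with compound 3 remains open.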